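The source may hold more compounds than are shown below. What is called first, only, known or untested is meant among the compounds shown, and "the series" means these compounds.

compound 1 `COc1ccc(S(C)(=O)=O)c(NCC2=NCCN2)c1`: < 6310 nM
compound 2 `CS(=O)(=O)c1ccc(F)cc1NCC1=NCCN1`: < 6310 nM
compound 3 `CC(C)S(=O)(=O)c1ccccc1NCC1=NCCN1`: < 6310 nM

In an assay on CHO cells for binding affinity to Alpha-2B adrenergic receptor (Homo sapiens), read by radioligand binding (a higher number here means a weaker inhibitor, a lower number a stronger inhibitor), compound 1 gives < 6310 nM, which is a limit of the assay and not a number. Compound 2 likewise gives < 6310 nM, a limit. Compound 3 gives < 6310 nM, again a limit. Compound 1 therefore stands at the limit of < 6310 nM in this assay, at which 3 of the 3 values shown sit, and nothing places it anywhere more exactly. Compound 4 `COc1ccc(SC)c(NCC2=NCCN2)c1` differs from compound 1 by methylsulfanyl in place of methylsulfonyl on an aromatic carbon. Going by the values given here, the only measured step, a step that the two limits leave unreadable from compound 1 to compound 2, changes a different group and cannot be read, so no measured step bears on the present change. Compound 4 is expected to give 3000 nM, within 500 nM to 20000 nM. The expected change from compound 1 is a step that the limit leaves unreadable from compound 1 to compound 4, with a large chance that only a limit is reported.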

Compound 4, inhibition constant: < 6310 nM
Compound 4: only a limit was reported (the forecaster's own chance of this, stated with the estimate: 60%); the middle value does not contradict the limit.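

Going by these compounds alone, compound 1 and compound 4 each give only a limit in this assay, and no step between them can be read. What methylsulfanyl in place of methylsulfonyl changes, and where any compound shown truly stands, stays open: the limit of < 6310 nM in this assay, at which 4 of the 4 values shown sit.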